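The source may hold more compounds than are shown below. What is called first, only, known or untested is meant among the compounds shown, and "the series" means these compounds.

In a functional assay on HeLa cells (Homo sapiens) for inhibition, read by CCK-8 assay, with a stated time of 48 h (on this read-out lower numbers stand for stronger inhibition and higher numbers for weaker inhibition), three compounds that share one core have been measured. Compound 1 (`COc1cc(-c2ccnc3cc(-c4ccc5c(ccn5C)c4)nn23)cc(OC)c1OC`) gives 19 nM and compound 2 (`COc1cc(-c2ccnc3cc(-c4ccc5cc[nH]c5c4)nn23)cc(OC)c1OC`) gives 125 nM while compound 3 (`COc1cc(-c2ccnc3cc(-c4ccc(C(F)(F)F)cc4)nn23)cc(OC)c1OC`) gives 1840 nM as the highest of the three numbers, which makes it the weakest so far. Compound 4 (`COc1cc(-c2ccnc3cc(-c4cccc(C)c4)nn23)cc(OC)c1OC`) carries 3-methylphenyl in place of the 4-(trifluoromethyl)phenyl of compound 3 on an aromatic carbon (3-methylphenyl in place of 4-(trifluoromethyl)phenyl on an aromatic carbon). For the measured compounds named here, all the measured steps change the group at this same carbon. The swap of one indolyl group for the other gave a modest step (a 6.6-fold higher number from compound 1 to compound 2 (0.82 log units; beyond the scatter)), and putting in 4-(trifluoromethyl)phenyl gave two large ones (a 97-fold higher number from compound 1 to compound 3 (1.99 log units; beyond the scatter) and a 15-fold higher number from compound 2 to compound 3 (1.17 log units; beyond the scatter)). Going by the values given here, no measured compound shows what a methyl group on the phenyl does, so the evidence is indirect. Compound 4 remains a phenyl compound, so no return to the level of compound 2 (125 nM) is expected. A modest step toward a lower number is expected (a 2.6-fold lower number from compound 3 to compound 4 (0.42 log units; beyond the scatter)) in this assay for this swap. The estimate for compound 4 is 700 nM with an expected range from 180 nM to 2500 nM in this read-out.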

Compound 4, half-maximal inhibitory concentration: 4230 nM
Estimate against measurement, compound 4: 6.0-fold (0.78 log units) below; the whole stated range lies below it.
By their numbers in this assay, from the lowest: compound 1; then compound 2; then compound 3; then compound 4.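

In this assay, the swap to 3-methylphenyl gives a 2.3-fold higher number from compound 3 to compound 4 (0.36 log units; beyond the scatter), so this second phenyl compound is not stronger than the first, and compound 4 is the weakest of the four. The gap to the indolyl groups also holds for this new phenyl group, with a 34-fold higher number from compound 2 to compound 4 (1.53 log units; beyond the scatter) and a 220-fold higher number from compound 1 to compound 4 (2.35 log units; beyond the scatter), so both indolyl compounds stand well below both phenyl compounds at this carbon. No supporting measurement bears on what lies behind these differences.

From the compounds shown here alone, the step from compound 3 to compound 4 changes both the group on the phenyl ring and its place, so the effect of each alone stays open. A matched pair such as 4-methylphenyl or 3-(trifluoromethyl)phenyl, or plain phenyl as a reference, would separate them.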